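Moving compound 3 away from 4-cyanophenyl

A few compounds are considered here, and "the series" means these few. Any claim that something is new, unique, unknown or untested is made for them only; others in the source may bear on it.

Measured so far in a functional assay (muscle tissue) with Cavia porcellus as the target; on this read-out higher numbers stand for an effect only at larger amounts of compound and lower numbers for an effect already at smaller amounts
- compound 1 `COC(=O)C1=C(C)N=C(C)/C(=C(\O)OC)C1c1cccc(Br)c1` gives 1.29 nM
- compound 2 `CCc1ccccc1C1C(C(=O)OC)=C(C)N=C(C)/C1=C(\O)OC` gives 6.46 nM
- compound 3 `COC(=O)C1=C(C)N=C(C)/C(=C(\O)OC)C1c1ccc(C#N)cc1` gives 3470 nM

Compound 3 stands highest of the three at 3470 nM and is the only one carrying 4-cyanophenyl. The next compound, compound 4 `COC(=O)C1=C(C)N=C(C)/C(=C(\O)OC)C1c1ccc(Cl)cc1Cl`, has 2,4-dichlorophenyl in place of 4-cyanophenyl on a saturated ring carbon. Within the data shown here, two measured steps bear on this change: a 2700-fold higher number from compound 1 to compound 3 (3.43 log units; beyond the scatter) and a 540-fold higher number from compound 2 to compound 3 (2.73 log units; beyond the scatter) are both large, and both end at the 4-cyanophenyl compound. By contrast, a 5.0-fold higher number from compound 1 to compound 2 (0.70 log units; beyond the scatter) is modest, so the two compounds without 4-cyanophenyl lie much closer together. Among the measured compounds shown here, no measured compound carries 2,4-dichlorophenyl, which leaves the size of the change uncertain. On the strength of those two large steps, a large move to a lower number is expected in this assay, estimated as a 140-fold lower number from compound 3 to compound 4 (2.14 log units; beyond the scatter) in size. Compound 4 is expected at 25 nM with an estimated range from 3 nM to 250 nM as the upper end.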

Compound 4, half-maximal effective concentration: 640 nM
Beside the measured number, compound 4's estimate is 26-fold (1.41 log units) below it; measured number outside the range, above it.
By their numbers in this assay, from the lowest: compound 1; then compound 2; then compound 4; then compound 3.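

In this assay, 2,4-dichlorophenyl brings only a modest gain over 4-cyanophenyl on the saturated ring carbon (a 5.4-fold lower number from compound 3 to compound 4 (0.73 log units; beyond the scatter)), and compound 4 stays far from the two compounds with low numbers (a 99-fold higher number from compound 2 to compound 4 (2.00 log units; beyond the scatter); a 500-fold higher number from compound 1 to compound 4 (2.70 log units; beyond the scatter)). The large gap around compound 3 is therefore not tied to 4-cyanophenyl alone, since a phenyl group without a nitrile can also give a high number at this place. No measurement available here accounts for the spread among these four phenyl groups.

Open, on these data alone, is how 2-chlorophenyl or 4-chlorophenyl would compare with compound 4, which would separate the contributions of the two chlorines. Also open, as far as these compounds go, is whether 3-cyanophenyl would stay near compound 3 or move towards compound 1.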